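Swapping Methyl for Trifluoromethyl on a Chromone Ether

The source may hold more compounds than are shown below. What is called first, only, known or untested is meant among the compounds shown, and "the series" means these compounds.

Of the compounds shown here, three sharing one core have been measured in an assay on microsomes for inhibition of Amine oxidase [flavin-containing] B (Homo sapiens), read by fluorescence and spectrophotometry, with a stated time of 20 min; on this read-out higher numbers stand for weaker inhibition and lower numbers for stronger inhibition. Compound 1, `O=c1ccoc2ccc(OCCc3ccccc3)cc12`, gives 21 nM. Compound 2, `O=c1ccoc2ccc(OCc3cccc(Br)c3)cc12`, gives 2 nM. Compound 3, `Cc1ccc(COc2ccc3occc(=O)c3c2)cc1`, gives 6 nM in this assay. On these numbers compound 3 stands second highest of the three: compound 2 sits at a lower value, a gap beyond the usual scatter of repeated measurements, while compound 1 sits at a higher value, also beyond the scatter. Compound 3 is thus neither the strongest nor the weakest inhibitor of this small set.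

Compound 4, `O=c1ccoc2ccc(OCc3ccc(C(F)(F)F)cc3)cc12`, has not yet been measured in this assay. It differs from compound 3 in one place: trifluoromethyl in place of methyl on an aromatic carbon. Going by the values given here, no pair of measured compounds differing in exactly this way is available, so the size of the step cannot be read from the data. Since compounds 2 and 3 with different substituents on that ring both reach low values, the step from compound 3 to compound 4 is expected to be small, a 1.2-fold lower number from compound 3 to compound 4 (0.08 log units; within the scatter), likely within the scatter in either direction. Compound 4 is therefore estimated at 5 nM, with a plausible range from 1.5 nM to 15 nM.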

Compound 4, half-maximal inhibitory concentration: 2 nM
Compound 4: middle estimate off by 2.5-fold (0.40 log units), on the high side; low and high end bracket the measured number.
By their numbers in this assay, from the lowest: compounds 2 and 4 (each within the scatter of the next); then compound 3; then compound 1.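

In this assay, going by these compounds alone, the step from methyl to trifluoromethyl gives the first direct reading of a change at this spot, on an aromatic carbon para to a large group: a 3.0-fold lower number from compound 3 to compound 4 (0.48 log units; beyond the scatter). The step is modest but lies beyond the usual scatter, and since a lower number means stronger inhibition, the swap improves inhibition rather than merely preserving it. The earlier compounds shown here could not show this, as no measured pair differed in only one place, and here a group of 4 heavy atoms replaces one of 1 heavy atom with no loss of inhibition. Nothing measured here explains why the swap strengthens inhibition.

This single step speaks only for methyl and trifluoromethyl at this position on this scaffold, so it cannot show a trend across other groups. From the compounds shown here alone, whether an amine, a carboxylic acid or a longer chain in the same place would keep, strengthen or weaken inhibition remains open.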